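The source may report more compounds than this note shows. Statements on the series, on what has been measured and on what is new or still open speak of the compounds shown alone.

Measured so far in a functional assay on ACHN cells (Homo sapiens) for inhibition, read by sulforhodamine B assay, with a stated time of 48 h, tested at 10 uM; on this read-out lower numbers stand for less inhibition and higher numbers for more inhibition at the one concentration tested (going by the name of the read-out):
compound 1 `c1ccc(-c2cn3ccnc3c(-c3ccc4ncn(C5CCCCC5)c4c3)n2)cc1`: 35.9%
compound 2 `O=Cc1ccc(-c2cn3ccnc3c(-c3ccc4ncn(C5CCCCC5)c4c3)n2)cc1`: 11.6%

Among the measured compounds shown here, compound 2 stands lowest of the two numbers, with compound 1 its only neighbour. The single step shown, a number 24.3 percentage points lower from compound 1 to compound 2 (beyond the scatter), lies beyond the scatter. Compound 3 `Fc1ccc(-c2cn3ccnc3c(-c3ccc4ncn(C5CCCCC5)c4c3)n2)cc1` differs from compound 2 by fluoro in place of formyl on an aromatic carbon. For the measured compounds named here, no measured step places fluoro at this carbon, so the expectation leans on that one step, which shows a group at this position can move the number; with the fewer heavy atoms entering, compound 3 is expected to land between the two measured values, as the expected step of a number 15.4 percentage points higher from compound 2 to compound 3 (beyond the scatter). Compound 3 is estimated at 27%, within a range from 8% to 46%.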

Compound 3, a percentage reported as inhibition, at one concentration (the size of the read-out at that concentration, not a potency): 9.02%
The estimate for compound 3 lay 18 percentage points above the measured number; the measured number falls inside the stated range.
By their numbers in this assay, from the lowest: compounds 3 and 2 (each within the scatter of the next); then compound 1.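

In this assay, fluoro on this aromatic carbon gives a number 26.9 percentage points lower from compound 1 to compound 3 (beyond the scatter), so the lower number is not confined to formyl. Fluoro in place of formyl gives a number 2.6 percentage points lower from compound 2 to compound 3 (within the scatter), so this assay does not separate the 4-formylphenyl and 4-fluorophenyl compounds, despite their different heavy-atom and hydrogen-bond acceptor counts. Nothing available bears on the reason for either step.

Still open, going by these compounds, is whether an amine or a carboxylic acid at this carbon would read near compound 1 or near compound 2 and compound 3.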